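The source may report more compounds than this note shows. Statements on the series, on what has been measured and on what is new or still open speak of the compounds shown alone.

In a functional assay on HCT-116 cells (Homo sapiens) for antiproliferative activity, read by MTT assay, with a stated time of 72 h (a lower number here means a stronger inhibitor, a higher number a weaker inhibitor), three compounds sharing one core and differing on the ring amide nitrogen have been measured. Compound 1 `COc1cccc(N2C(=O)COc3ccc(-c4cnc(Cl)c(NS(=O)(=O)c5ccc(F)cc5)c4)cc32)c1` gives > 40000 nM, which is a limit of the assay and not a number. Compound 2 `CC(C)N1C(=O)COc2ccc(-c3cnc(Cl)c(NS(=O)(=O)c4ccc(F)cc4)c3)cc21` gives 18900 nM and compound 3 `Cc1ccc(N2C(=O)COc3ccc(-c4cnc(Cl)c(NS(=O)(=O)c5ccc(F)cc5)c4)cc32)cc1` gives 34300 nM, two values within the scatter of each other. Within the data shown here, only one measured step, an at least 2.1-fold lower number from compound 1 to compound 2 (0.32 log units; beyond the scatter), lies beyond the scatter. The floor of an at least 1.1-fold lower number from compound 1 to compound 3 (0.06 log units; that floor lies within the scatter) lies within it, as does a 1.8-fold higher number from compound 2 to compound 3 (0.26 log units; within the scatter).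

Compound 4 `O=C1COc2ccc(-c3cnc(Cl)c(NS(=O)(=O)c4ccc(F)cc4)c3)cc2N1c1ccc(Cl)cc1` has chloro in place of methyl on an aromatic carbon, turning 4-methylphenyl into 4-chlorophenyl (chloro in place of methyl on an aromatic carbon). Among the measured compounds shown here, no measured step makes this exact exchange. The two steps leading to compound 3 bear on it most closely, and neither is shown to exceed the scatter, so no step beyond the scatter is expected in this assay. The estimated step is a 1.1-fold lower number from compound 3 to compound 4 (0.06 log units; within the scatter). Compound 4 is expected to give 30000 nM, with an estimated range of 15000 nM to 40000 nM.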

Compound 4, half-maximal inhibitory concentration: 27900 nM
Estimate against measurement, compound 4: 1.1-fold (0.03 log units) above; measured number inside the range.
By their numbers in this assay, from the lowest: compounds 2, 4 and 3 (each within the scatter of the next). At a limit, above all of these: compound 1.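

In this assay, exchanging only the substituent on the aromatic ring, and not the whole group on the ring amide nitrogen, changes little: a 1.2-fold lower number from compound 3 to compound 4 (0.09 log units; within the scatter), so at this place, para to a large group, chloro and methyl are not told apart. The 4-chlorophenyl group does not separate from isopropyl on that nitrogen either, with a 1.5-fold higher number from compound 2 to compound 4 (0.17 log units; within the scatter). The step from the 3-methoxyphenyl compound, an at least 1.4-fold lower number from compound 1 to compound 4 (0.15 log units; that floor lies within the scatter), gives only a floor and cannot be read as a size, since it starts from a limit and not a number: the limit of > 40000 nM in this assay, at which 1 of the 4 values shown sits.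

On these data alone, whether an amine or a carboxylic acid at this place on the aromatic ring would move the number beyond the scatter stays open. So does the effect of a longer chain in place of isopropyl on the ring amide nitrogen.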